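Opening the amide end of compound 2 to an aminoethyl chain

The source may hold more compounds than are shown below. What is called first, only, known or untested is meant among the compounds shown, and "the series" means these compounds.

Measured compounds:
compound 1 `CCc1nn(CC)c(C2CCN(C(=O)CN3CN(c4ccccc4)C4(CCN(C(=O)c5ccc(C6CCCCC6)cc5)CC4)C3=O)CC2)c1C` — "not determined" (no result reported)
compound 2 `O=C(CN1CN(c2ccccc2)C2(CCN(C(=O)c3ccc(C4CCCCC4)cc3)CC2)C1=O)N1CCCCC1` — 1100 nM
compound 3 `CC(C)(C)OC(=O)NC1CCCN(C(=O)CN2CN(c3ccccc3)C3(CCN(C(=O)c4ccc(C5CCCCC5)cc4)CC3)C2=O)C1` — 4400 nM

In an assay on HEK293 cells for displacement of a labelled ligand from NPC1-like intracellular cholesterol transporter 1 (Homo sapiens) (a higher number here means a weaker inhibitor, a lower number a stronger inhibitor), compound 2 gives 1100 nM, the lowest number of the two reported, while compound 3 gives 4400 nM. Among the compounds with values here, the only measured step, a 4.0-fold higher number from compound 2 to compound 3 (0.60 log units; beyond the scatter), shows that adding a substituent on the saturated ring at this position costs affinity. Compound 4 `NCCNC(=O)CN1CN(c2ccccc2)C2(CCN(C(=O)c3ccc(C4CCCCC4)cc3)CC2)C1=O` differs from compound 2 as follows: (2-aminoethyl)amino in place of piperidin-1-yl on a carbonyl carbon. Within the data shown here, no measured step exchanges the ring itself, so the step from compound 2 to compound 3 is the nearest guide. Because of a 4.0-fold higher number from compound 2 to compound 3 (0.60 log units; beyond the scatter), a modest weakening is expected, estimated as a 2.3-fold higher number from compound 2 to compound 4 (0.36 log units; beyond the scatter). Compound 4 is therefore expected to give 2500 nM in this assay, within 800 nM to 8000 nM.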

Compound 4, half-maximal inhibitory concentration: 3800 nM
Estimate against measurement, compound 4: 1.5-fold (0.18 log units) below; the measured number falls inside the stated range.
By their numbers in this assay, from the lowest: compound 2; then compounds 4 and 3 (each within the scatter of the next).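

In this assay, the open (2-aminoethyl)amino chain in place of piperidin-1-yl on the carbonyl carbon gives a 3.5-fold higher number from compound 2 to compound 4 (0.54 log units; beyond the scatter) and the value stays measurable, so this ring is not required for a measured value here. The earlier step changed only a substituent on the ring, whereas this one shows that removing the ring also raises the number. Nothing at hand explains this step. The compounds shown do not separate the loss of the ring from the arrival of the terminal amine. They also leave open how a carboxylic acid or a longer chain at this carbonyl carbon would compare.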